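Three Esters Beyond the Limit and a Fourth Expected There

The source may report more compounds than this note shows. Statements on the series, on what has been measured and on what is new or still open speak of the compounds shown alone.

Measured compounds:
compound 1 `C=C1[C@H](OC(C)=O)[C@@H](OC(C)=O)[C@@H](OC(C)=O)C(C)(C)/C=C/[C@H](C)[C@H](OC(=O)c2ccccc2)[C@@]2(O)C[C@@](C)(O)[C@H](OC(C)=O)[C@@H]2[C@H]1OCC(C)C`: > 100000 nM
compound 2 `C=C1[C@H](OC(C)=O)[C@@H](OC(=O)c2cccc(C)c2)[C@@H](OC(C)=O)C(C)(C)/C=C/[C@H](C)[C@H](OC(=O)c2ccccc2)[C@@]2(O)C[C@@](C)(O)[C@H](OC(C)=O)[C@@H]2[C@H]1OCC(C)C`: > 100000 nM
compound 3 `C=C1[C@H](OC(C)=O)[C@@H](OC(=O)c2cccc(C)c2)[C@@H](OC(C)=O)C(C)(C)/C=C/[C@H](C)[C@H](OC(=O)c2ccccc2)[C@@]2(O)C[C@@](C)(OC(C)=O)[C@H](OC(C)=O)[C@@H]2[C@H]1OCC(C)C`: > 100000 nM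

In a functional assay on NCI/ADR-RES cells (Homo sapiens) for antiproliferative activity, read by MTT assay, with a stated time of 48 h (a higher number here means a weaker inhibitor, a lower number a stronger inhibitor), compound 1 gives > 100000 nM, which is a limit of the assay and not a number. Compound 2 likewise reaches only a limit in this assay, > 100000 nM. Compound 3 too stays at a limit, > 100000 nM. Hence the step that the two limits leave unreadable from compound 2 to compound 1, the change (methyl in place of 3-methylphenyl on a carbonyl carbon), cannot be read, and the same holds for a step that the two limits leave unreadable from compound 2 to compound 3, the change (acetyl in place of hydrogen on an oxygen on a saturated carbon), which is also how the core of compound 3 differs from the core of compound 2.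

Compound 4 `C=C1[C@H](OC(C)=O)[C@@H](OC(C)=O)[C@@H](OC(C)=O)C(C)(C)/C=C/[C@H](C)[C@H](OC(=O)c2ccccc2)[C@@]2(O)C[C@@](C)(OC(C)=O)[C@H](OC(C)=O)[C@@H]2[C@H]1OCC(C)C` is not yet measured. It differs from compound 3 by methyl in place of 3-methylphenyl on a carbonyl carbon, the same change as from compound 2 to compound 1, at a place that reads the same in both pairs. Compound 4 is expected to sit beside that earlier unreadable step, a step that the limit leaves unreadable from compound 3 to compound 4, an expectation resting on the fact that every measured value, compound 3 included, sits at the limit of > 100000 nM in this assay, at which 3 of the 3 values shown sit. Compound 4 is therefore estimated at 150000 nM, within 100000 nM to 600000 nM, most probably reported again only as a limit.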

Compound 4, half-maximal inhibitory concentration: > 100000 nM
Compound 4 gave a limit, no number (the forecaster's own chance of this, stated with the estimate: 90%); the middle value does not contradict the limit.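

In this assay compound 4 gives > 100000 nM, a limit of the assay and not a number. Neither the comparison of compound 3 with compound 4 nor that of compound 1 with compound 4 yields a readable step. The compounds shown leave open what either change does to activity, since every value is only a limit: the limit of > 100000 nM in this assay, at which 4 of the 4 values shown sit.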